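Changing the aryl group of a quinoline thiosemicarbazone

A few compounds are considered here, and "the series" means these few. Any claim that something is new, unique, unknown or untested is made for them only; others in the source may bear on it.

Compound 1 `S=C(N/N=C/c1ccc2ccccc2n1)Nc1cccc(Cl)c1`: 52500 nM
Compound 2 `CN(C)C(=S)N/N=C/c1nc2ccccc2s1`: 2100 nM
Compound 3 `CN(C)C(=S)N/N=C/c1ccc2cccnc2n1`: 970 nM

All three compounds were tested in a functional assay on HeLa cells (Homo sapiens) for antiproliferative activity, read by sulforhodamine B assay, with a stated time of 72 h; on this read-out lower numbers stand for stronger inhibition and higher numbers for weaker inhibition. Compound 1 gives 52500 nM, the highest of the three numbers, which makes it the weakest of the set. Compound 2 gives 2100 nM and compound 3 gives 970 nM, both lying beyond the scatter from compound 1. Within the data shown here, neither of them differs from compound 1 in a single place, so no step between measured compounds is available as a guide.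

Compound 4 `COc1ccc(NC(=S)N/N=C/c2ccc3ccccc3n2)cc1` is the next compound to be considered. It differs from compound 1 in one place: 4-methoxyphenyl in place of 3-chlorophenyl on an amide-type nitrogen. Among the measured compounds shown here, nothing among the measured compounds shows how this exchange on the amide-type nitrogen affects the read-out; compound 2 and compound 3 carry a different group on that nitrogen and a different core as well, so they say nothing about it. Without a comparable step, the expectation for compound 4 rests on compound 1 alone. For compound 4 the step that this estimate means is expected to be a 1.3-fold lower number from compound 1 to compound 4 (0.12 log units; within the scatter), nothing beyond the scatter in either direction. Compound 4 is therefore estimated at 40000 nM, with a range from 10000 nM to 150000 nM.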

Compound 4, half-maximal inhibitory concentration: 72600 nM
Compound 4: the middle estimate sits 1.8-fold (0.26 log units) below what was measured; measured number inside the range.
By their numbers in this assay, from the lowest: compound 3; then compound 2; then compounds 1 and 4 (each within the scatter of the next).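

Among these compounds, at the amide-type nitrogen of the shared core, the change from 3-chlorophenyl to 4-methoxyphenyl in this assay gives a 1.4-fold higher number from compound 1 to compound 4 (0.14 log units; within the scatter), the first step in this set that can be read at this position. The two aryl groups are not told apart by this read-out, even though 4-methoxyphenyl is the larger group by heavy atoms and brings a hydrogen-bond acceptor that 3-chlorophenyl lacks, so this position tolerates that difference between these two groups without a shift beyond the scatter. Why the two groups read alike cannot be said, since no measurement at hand bears on the question.

Among the compounds shown here, this single step compares only two substituted phenyl groups, so it remains open whether a different kind of group on this nitrogen, such as a carboxylic acid on the phenyl ring, a morpholine ring or a longer alkyl chain, would move the number beyond the scatter. From the compounds shown here alone, it also remains open whether the same exchange would read the same way on the cores of compound 2 and compound 3, which differ from compound 1 and compound 4 in more than one place.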